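Hydroxy on the fused ring of compound 1

A few compounds are considered here, and "the series" means these few. Any claim that something is new, unique, unknown or untested is made for them only; others in the source may bear on it.

Values in a functional assay on A549 cells (Homo sapiens) for antiproliferative activity, read by MTT assay; on this read-out lower numbers stand for stronger inhibition and higher numbers for weaker inhibition:
- compound 1 `Cc1nn2c(-c3nc4ccccc4[nH]3)c(-c3ccccc3)nc2s1`: 16600 nM
- compound 2 `Cc1nn2c(-c3nc4ccccc4[nH]3)c(-c3ccc(F)cc3)nc2s1`: > 30000 nM

Going by the values given here, compound 1 gives 16600 nM, the only true number so far in this assay. Compound 2 gives > 30000 nM, which is a limit of the assay and not a number; this is the limit of > 30000 nM in this assay, at which 1 of the 2 values shown sits.

Compound 3 `Cc1nn2c(-c3nc4cc(O)ccc4[nH]3)c(-c3ccccc3)nc2s1` is the next to be read, and it departs from compound 1 by one change: hydroxy in place of hydrogen on an aromatic carbon. The hydroxy stands on an aromatic carbon of a six-membered aromatic ring of carbon only, part of a fused system of two rings.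

Among the compounds with values here, the one measured step is an at least 1.8-fold higher number from compound 1 to compound 2 (0.25 log units; that floor lies within the scatter), for fluoro in place of hydrogen on an aromatic carbon. That step lies elsewhere in the molecule and involves a different group, so it offers only weak guidance. On these data alone, no step beyond the scatter is therefore expected in this assay, and the direction remains open.

The expected step is a 1.4-fold lower number from compound 1 to compound 3 (0.14 log units; within the scatter). For compound 3 the estimated value is 12000 nM, with an expected range of 3000 nM to 30000 nM.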

Compound 3, half-maximal inhibitory concentration: 19400 nM
Estimate against measurement, compound 3: 1.6-fold (0.21 log units) below; low and high end bracket the measured number.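

In this assay, hydroxy in place of hydrogen on an aromatic carbon of the six-membered aromatic ring of carbon only, meta to a fused ring and para to a fused ring, gives a 1.2-fold higher number from compound 1 to compound 3 (0.07 log units; within the scatter), so this change at this position does not separate compound 3 from compound 1. Going by these compounds alone, this is the first step that rests on two true numbers, and it shows that this ring position takes a hydroxy with no shift beyond the scatter. Compound 2 remains a limit of the assay and not a number, so the series still holds one value that gives only a floor for its step: the limit of > 30000 nM in this assay, at which 1 of the 3 values shown sits.

On these data alone, whether a different group at this position, such as an amine, a methoxy or a carboxylic acid, would move the number beyond the scatter remains open, as does the effect of hydroxy elsewhere on this ring. Also open, as far as these compounds go, is whether any change to the core of compound 1, which gives 16600 nM, can produce a step beyond the scatter toward stronger inhibition.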